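Cyclopropylamino replaces tert-butyl on the carbonyl carbon

The source may hold more compounds than are shown below. What is called first, only, known or untested is meant among the compounds shown, and "the series" means these compounds.

In an assay on isolated protein for inhibition of Gonadotropin-releasing hormone receptor (Rattus norvegicus) (a lower number here means a stronger inhibitor, a higher number a weaker inhibitor), compound 1 `COc1ccc([N+](=O)[O-])cc1CSc1nc2cc(NC(=O)NC(C)(C)C)ccc2n1C1CC1` gives 860 nM. Compound 2 `COc1ccc([N+](=O)[O-])cc1CSc1nc2cc(NC(=O)NC(C)(C)C)ccc2n1-c1ccccc1` reaches only a limit of this assay, > 2600 nM. The step of an at least 3.0-fold higher number from compound 1 to compound 2 (0.48 log units; beyond the scatter) shows that phenyl in place of cyclopropyl on the aromatic nitrogen weakens inhibition. Compound 3 `COc1ccc([N+](=O)[O-])cc1CSc1nc2cc(NC(=O)C(C)(C)C)ccc2n1C(C)C` also stands at a limit of this assay, > 10000 nM. Compound 4 `COc1ccc([N+](=O)[O-])cc1CSc1nc2cc(NC(=O)NC3CC3)ccc2n1C(C)C` differs from compound 3 by cyclopropylamino in place of tert-butyl on a carbonyl carbon. For the measured compounds named here, no measured step covers this change; the single measured step concerns the aromatic nitrogen instead. Compound 4 is nevertheless expected to inhibit more strongly than compound 3, with an estimated step of an at least 3.3-fold lower number from compound 3 to compound 4 (0.52 log units; beyond the scatter), because compound 1, which also carries an amino group on that carbonyl carbon, gives 860 nM. The estimate for compound 4 is 3000 nM, between 700 nM and 12000 nM.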

Compound 4, half-maximal inhibitory concentration: 1600 nM
Compound 4: the middle estimate sits 1.9-fold (0.27 log units) above what was measured; low and high end bracket the measured number.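

For the compounds shown here, on the carbonyl carbon, cyclopropylamino in place of tert-butyl gives an at least 6.2-fold lower number from compound 3 to compound 4 (0.79 log units; beyond the scatter), the only measured step at this place, since the earlier step concerned the aromatic nitrogen. Compound 3 stands at a limit, so this step is a bound and not an exact size: the limit of > 10000 nM in this assay, at which 1 of the 4 values shown sits.

The compounds shown do not tell whether the gain follows the entering nitrogen with its hydrogen-bond donor or the three-membered ring. A plain cyclopropyl or a methylamino group on that carbonyl carbon would separate the two, and neither is among these compounds.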